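Removing One Fluorine: Expected Shift in Lipophilicity

A few compounds are considered here, and "the series" means these few. Any claim that something is new, unique, unknown or untested is made for them only; others in the source may bear on it.

In a physicochemical assay for lipophilicity, in phosphate buffer, measured as octanol-water partition, with a stated time of 24 h (on this read-out lower numbers stand for lower lipophilicity and higher numbers for higher lipophilicity), compound 1 `S=C(N/N=C/c1ccc(Oc2ccc(Br)cc2)cc1)Nc1ccccc1` gives 5.62, while compound 2 `Fc1ccc(NC(=S)N/N=C/c2ccc(Oc3ccc(F)cc3)cc2)cc1` gives 5.19. Compound 2 stands lower of the two measured values, and compound 1 sits higher by a margin beyond the usual scatter. Compound 3 `Fc1ccc(Oc2ccc(/C=N/NC(=S)Nc3ccccc3)cc2)cc1` has not yet been measured. It differs from compound 2 in one place: hydrogen in place of fluoro on an aromatic carbon. Among the measured compounds shown here, no measured pair shows this step directly, so a small decrease, not beyond the scatter, is expected. The expected step of a number 0.14 log units lower from compound 2 to compound 3 (within the scatter) is a slight fall. Compound 3 is expected to give 5.05, between 4.75 and 5.35.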

Compound 3, partition coefficient: 5.09
Beside the measured number, compound 3's estimate is 0.04 log units below it, and the stated range covers the measured number.
By their numbers in this assay, from the lowest: compounds 3 and 2 (each within the scatter of the next); then compound 1.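

In this assay the change from 4-fluorophenyl to phenyl gives a number 0.10 log units lower from compound 2 to compound 3 (within the scatter) and so cannot be told apart from the noise of repeated measurements at this position. Fluoro in place of bromo on an aromatic carbon, a change in a different place, gives a number 0.53 log units lower from compound 1 to compound 3 (beyond the scatter) and stands clear of that noise. No measurement here explains either step. Still open, as far as these compounds go, is whether an amine or a carboxylic acid on this aromatic carbon would give a step beyond the scatter.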